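Adding a Second Chloro Group to the Core of Compound 3

The source may report more compounds than this note shows. Statements on the series, on what has been measured and on what is new or still open speak of the compounds shown alone.

Compound 1 `COc1cccc(S(=O)(=O)/C=C/c2ccccn2)c1` was tested in an assay on U2OS cells for activation of nuclear factor erythroid 2-related factor 2 (Homo sapiens), read by chemiluminescence, with a stated time of 6 h (a higher number here means that more compound is needed for the effect, a lower number that less compound is needed), where compound 1 gives 2170 nM. Compound 2 `COc1cccc(S(=O)(=O)/C=C/c2cccc(Cl)n2)c1` differs from it by one change: chloro in place of hydrogen on an aromatic carbon In this assay compound 2 gives 786 nM, so the change brought a 2.8-fold lower number from compound 1 to compound 2 (0.44 log units; beyond the scatter).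

Compound 3 `COc1ccccc1S(=O)(=O)/C=C/c1cccnc1Cl` is built on a different core; the difference between the two cores is not broken down here. In this assay compound 3 gives 849 nM, a number close to that of compound 2 and within the usual scatter of it, while against compound 1 it is a lower number that lies beyond the scatter.

Compound 4 `COc1ccccc1S(=O)(=O)/C=C/c1ccc(Cl)nc1Cl` has not been measured. Going by the values given here, it differs from compound 3 in one place: chloro in place of hydrogen on an aromatic carbon This is the same kind of change as the one from compound 1 to compound 2, though not the same: in compound 2 the entering chloro sits meta to a large group, whereas in compound 4 it sits meta to a chloro group and para to a large group.

The step of a 2.4-fold lower number from compound 3 to compound 4 (0.38 log units; beyond the scatter) is what he expects, set beside the measured 2.8-fold lower number from compound 1 to compound 2 (0.44 log units; beyond the scatter), and it rests on the value of compound 3 849 nM together with the gain seen from compound 1 to compound 2 a 2.8-fold lower number from compound 1 to compound 2 (0.44 log units; beyond the scatter). In this assay compound 4 is therefore estimated at 350 nM, expected to fall between 120 nM and 1000 nM.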

Compound 4, half-maximal effective concentration: 178 nM
The estimate for compound 4 lay 2.0-fold (0.29 log units) above the measured number; low and high end bracket the measured number.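

In this assay, chloro in place of hydrogen on an aromatic carbon brought a 4.8-fold lower number from compound 3 to compound 4 (0.68 log units; beyond the scatter) and thus lowered the number on the second core as well, with the two steps no further apart than repeated measurements of such steps would allow: the same change on two cores in this assay, a 2.8-fold lower number (0.44 log units; beyond the scatter) from compound 1 to compound 2 and a 4.8-fold lower number (0.68 log units; beyond the scatter) from compound 3 to compound 4, 1.7-fold (0.24 log units) apart, within the scatter of two such steps. Within this series, then, the gain seen on the core of compound 1 carried over to the core of compound 3, and its size held within the scatter. This does not make a general rule, since it rests on a single pair of steps on two cores, the entering chloro does not occupy the same place in the two cases, and compound 4 already carries a chloro group on that ring, so the pair says nothing about why the number falls.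

The compounds shown leave open how an amine, a nitrile or a trifluoromethyl group would fare in place of the entering chloro on the six-membered aromatic ring with its one nitrogen. They also leave open whether the methoxy group could give way to a longer chain or a carboxylic acid without losing the effect in this assay.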